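This account rests on a few compounds, and the source may have more. Where it says the series, first, only, none or still open, it means among the compounds named here.

Measured so far in an ADME assay on HEK293 cells (Homo sapiens) for antiproliferative activity, read by MTT assay; on this read-out higher numbers stand for weaker inhibition and lower numbers for stronger inhibition
- compound 1 `Nc1c(C(=O)NC2CCCC2)oc2nc(-c3ccccc3)cc(C(F)(F)F)c12` gives 85000 nM
- compound 2 `Nc1c(C(=O)N/N=C/c2ccccc2)oc2nc(-c3cccs3)cc(C(F)(F)F)c12` gives 72000 nM
- compound 3 `Nc1c(C(=O)N/N=C/c2ccc(Br)cc2)oc2nc(-c3ccccc3)cc(C(F)(F)F)c12` gives 64000 nM

Compound 2 at 72000 nM stands within the scatter of both other compounds, so this assay sets no order among the three. Compound 4 `CCCNC(=O)c1oc2nc(-c3cccs3)cc(C(F)(F)F)c2c1N` keeps the rest of compound 2 and changes one group on the amide-type nitrogen a group of 3 heavy atoms (3 carbon; no ring) in place of a group of 8 heavy atoms (7 carbon, 1 nitrogen; one six-membered aromatic ring of carbon only), on an amide-type nitrogen so that propyl enters there. Among the compounds with values here, no measured compound carries propyl. Within the data shown here, the one measured step at this kind of nitrogen is a 1.3-fold lower number from compound 1 to compound 3 (0.12 log units; within the scatter) and it also exchanges a group with a six-membered aromatic ring of carbon only for one without such a ring, read in reverse. That step is small and stays within the scatter, so it gives no reason to expect a shift in either direction. For compound 4 the expected change is a 1.0-fold higher number from compound 2 to compound 4 (0.02 log units; within the scatter) and thus none beyond the scatter. Compound 4 is estimated at 75000 nM with an expected range from 40000 nM to 125000 nM in this assay for now.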

Compound 4, half-maximal inhibitory concentration: 64000 nM
Beside the measured number, compound 4's estimate is 1.2-fold (0.07 log units) above it; the range from low to high includes it.
By their numbers in this assay, from the lowest: compounds 3, 4, 2 and 1 (each within the scatter of the next).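

In this assay the exchange of the group with the six-membered aromatic ring of carbon only and the double bond for propyl, on an amide-type nitrogen, is a 1.1-fold lower number from compound 2 to compound 4 (0.05 log units; within the scatter) and so makes no readable difference. Compound 1 and compound 3 both carry a ring on this nitrogen, whereas compound 4 shows that a group with no ring, and with no hydrogen-bond acceptor, also leaves the number within the scatter. Nothing measured here bears on why the number holds at this position.

No step at this nitrogen among the compounds shown goes beyond the scatter, so it remains open whether a longer chain, an amine or a carboxylic acid there would do so. Also open, from the compounds shown here alone, is whether propyl gives the same reading on the core of compound 1.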